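The source may hold more compounds than are shown below. What is called first, only, known or untested is meant among the compounds shown, and "the series" means these compounds.

Measured compounds:
Compound 1, `CC(C)=CCC[C@]1(C)/C=C/[C@@H](OC(=O)C=C(C)C)[C@](C)(O)/C=C/C(=O)/C(CCl)=C\C1`: 150 nM
Compound 2, `CC(C)=CCC[C@]1(C)/C=C/[C@@H](OC(=O)C=C(C)C)[C@](C)(O)/C=C/C(=O)/C(C[Si](c2ccccc2)(c2ccccc2)C(C)(C)C)=C\C1`: 13000 nM
Compound 3, `CC(C)=CCC[C@](C)(/C=C/[C@@H](OC(=O)C=C(C)C)[C@](C)(O)/C=C/C(=O)/C=C/N(C)C)CC=O`: 11200 nM

All three were tested in a functional assay on A549 cells (Homo sapiens) for antiproliferative activity, read by MTT assay, with a stated time of 48 h; a higher number here means a weaker inhibitor, a lower number a stronger inhibitor. Among them, compound 1 has the lowest number, so it is the strongest inhibitor of the set. Compound 3 comes nearest to it, and compound 2 lies furthest away; both gaps are well beyond the scatter of repeated measurements, so compound 1 clearly stands apart.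

The compound still to be measured is compound 4, `CC(C)=CCC[C@]1(C)/C=C/[C@@H](OC(=O)C=C(C)C)[C@](C)(O)/C=C/C(=O)/C(C(=O)N(C(C)C)C(C)C)=C\C1`. It is compound 1 with one change: diisopropylcarbamoyl in place of chloromethyl on a double-bonded ring carbon. Among the compounds with values here, no pair of measured compounds differing in exactly one place is available, so there is no measured step to lean on directly. What the data do show is that compound 2, in which the chloromethyl group is also gone, gives 13000 nM in this assay, far weaker than compound 1. On that basis, the step from compound 1 to compound 4 is expected to be large and in the weaker direction, a 20-fold higher number from compound 1 to compound 4 (1.30 log units; beyond the scatter). In this assay compound 4 is therefore estimated at 3000 nM, with a plausible range from 500 nM to 20000 nM.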

Compound 4, half-maximal inhibitory concentration: 13500 nM
For compound 4 the middle estimate is 4.5-fold (0.65 log units) below the measured one, and the stated range covers the measured number.
By their numbers in this assay, from the lowest: compound 1; then compounds 3, 2 and 4 (each within the scatter of the next).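

Within the data shown here, this is the first direct reading of a single change at this double-bonded ring carbon: in this assay the swap of chloromethyl for diisopropylcarbamoyl costs a great deal of activity (a 90-fold higher number from compound 1 to compound 4 (1.95 log units; beyond the scatter)), so the group held at this carbon has a strong bearing on the result. The swap alters several things at once, since the two heavy atoms of chloromethyl leave, the nine of diisopropylcarbamoyl enter, and a carbonyl with one hydrogen-bond acceptor comes in, so this single step cannot show which of these differences matters. No measurement shown here accounts for the loss of activity.

Going by these compounds, it remains open whether a small amide such as dimethylcarbamoyl, or a plain methyl or hydroxymethyl group on the same carbon, would stay close to compound 1 at 150 nM or fall away as well. Bromomethyl and fluoromethyl at this carbon would test whether the chlorine itself counts or whether any small halogen-bearing group serves equally well.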